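Replacing the bromopyridyl arm of a pyrrolidine urea

A few compounds are considered here, and "the series" means these few. Any claim that something is new, unique, unknown or untested is made for them only; others in the source may bear on it.

Compound 1 `O=C(Nc1ccccc1Br)N[C@@H]1CCN(c2ccc(Br)cn2)C1` is measured in a functional assay for antagonist activity at transient receptor potential cation channel subfamily V member 1 (Rattus norvegicus), read by FLIPR (a lower number here means a less potent compound, a higher number a more potent compound, by a factor of ten per unit of this negative logarithm), at 7.2. Of the two numbers available, this is the lower, yet compound 2 `Cc1cccc2c1CCN2CCNC(=O)Nc1ccccc1Br` gives 7.4 in this assay, within the scatter of compound 1. Compound 3 `Cc1cccc(N2CC[C@H](NC(=O)Nc3ccccc3Br)C2)c1` reaches only a limit, < 6.8, in this assay (the limit of < 6.8 in this assay, at which 1 of the 3 values shown sits). Compound 4 `O=C(Nc1ccccc1Br)N[C@@H]1CCN(c2ccc(F)c(F)c2)C1` differs from compound 1 by 3,4-difluorophenyl in place of 5-bromopyridin-2-yl on an amine nitrogen in a ring. For the measured compounds named here, no measured pair shows the same change. Since compound 3, which also carries a six-membered aromatic ring of carbon only on that amine nitrogen, sits at the limit, a downward step beyond the scatter is expected, estimated as the step from compound 1 to compound 4 a number 0.40 log units lower from compound 1 to compound 4 (beyond the scatter). Compound 4 is therefore estimated at 6.8 in this assay, with a range from 6 to 7.6, and a fair chance that only a limit is reported.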

Compound 4, negative logarithm of the antagonist equilibrium constant: 8.1
Compound 4: middle estimate off by 1.30 log units, on the low side; measured number above the stated range.
By their numbers in this assay, from the lowest: compounds 1 and 2 (each within the scatter of the next); then compound 4. At a limit, below all of these: compound 3.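

In this assay the exchange of 5-bromopyridin-2-yl for 3,4-difluorophenyl on the amine nitrogen in the ring gives a number 0.90 log units higher from compound 1 to compound 4 (beyond the scatter) and so shows that this position can gain from a six-membered aromatic ring of carbon only. Such a ring does not guarantee that gain by itself. Compound 3, which also carries a ring of this kind on that nitrogen, is reported only as a limit: the limit of < 6.8 in this assay, at which 1 of the 4 values shown sits.

Which of the two fluorines accounts for the step remains open. So does the outcome with a single chlorine, a methoxy group or a saturated cyclohexyl ring on this nitrogen.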